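A few compounds are considered here, and "the series" means these few. Any claim that something is new, unique, unknown or untested is made for them only; others in the source may bear on it.

Measured in a functional assay on HCT-15 cells (Homo sapiens) for cytotoxicity, read by MTT assay, with a stated time of 2 days; a lower number here means a stronger inhibitor, a higher number a weaker inhibitor:
- Compound 1 `Cc1ccc2nc(-c3ccccc3N(C)C)[nH]c(=O)c2c1`: > 50000 nM
- Compound 2 `Cc1ccc2c(=O)[nH]c(-c3cccc(F)c3)nc2c1`: 14400 nM

Compound 1 gives > 50000 nM, which is a limit of the assay and not a number. Within the data shown here, compound 2, at 14400 nM, therefore holds the only actual number so far. Compound 3 `Cc1ccc2c(=O)[nH]c(-c3cccc(C(F)(F)F)c3)nc2c1` carries trifluoromethyl in place of fluoro on an aromatic carbon. Among the measured compounds shown here, no measured pair tests this change, so in this assay no shift beyond the scatter is expected, and no firm direction. The estimated step is a 1.0-fold lower number from compound 2 to compound 3 (0.01 log units; within the scatter). Compound 3 is expected at 14000 nM, with an estimated range of 5000 nM to 40000 nM.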

Compound 3, half-maximal inhibitory concentration: > 50000 nM
Compound 3 was reported as a limit; the forecaster's own chance of this, stated with the estimate: 15%; at least 3.5-fold (0.55 log units) between middle value and limit.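

Among these compounds, the first measured step at this position shows that the change matters here: trifluoromethyl in place of fluoro, on an aromatic carbon meta to a large group, gives an at least 3.4-fold higher number from compound 2 to compound 3 (0.54 log units; beyond the scatter). In this assay compound 3 gives > 50000 nM, a limit of the assay and not a number. The full size of the step therefore cannot be read: the limit of > 50000 nM in this assay, at which 2 of the 3 values shown sit.

Open, from the compounds shown here alone, is what a methoxy group or a chlorine atom at this place would give. Also open, going by these compounds, is whether any group here gives a lower number than compound 2.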